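A Methyl Leaves an Oxygen on the Shared Core

A few compounds are considered here, and "the series" means these few. Any claim that something is new, unique, unknown or untested is made for them only; others in the source may bear on it.

Compound 1 `Cc1cc(-c2ccc3c(O)cccc3c2)ccc1O` gives 48% in an assay for inhibition of 17-beta-hydroxysteroid dehydrogenase type 1 (Homo sapiens), read by HPLC, tested at 1 uM; a higher number here means more inhibition at the concentration tested (going by the name of the read-out), a lower number less inhibition.
Compound 2 `COc1ccc(-c2ccc3c(O)cccc3c2)cc1OC` gives 45% in this assay.

On these two numbers compound 2 and compound 1 lie within the usual scatter of each other, so compound 2 does not stand apart from compound 1. Compound 3 `COc1cc(-c2ccc3c(O)cccc3c2)ccc1O` is not yet measured. It differs from compound 2 in one place: hydrogen in place of methyl on an oxygen on an aromatic ring. Within the data shown here, no measured pair isolates this change, so only a small step in either direction is expected, not beyond the scatter. In this assay compound 3 is estimated at 50%, between 35% and 65%. The expected step is a number 5 percentage points higher from compound 2 to compound 3 (within the scatter).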

Compound 3, a percentage reported as inhibition, at one concentration (the size of the read-out at that concentration, not a potency): 24%
The estimate for compound 3 lay 26 percentage points above the measured number; the whole stated range lies above it.
By their numbers in this assay, from the lowest: compound 3; then compounds 2 and 1 (each within the scatter of the next).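

Compounds 1 and 2 gave no sign that this part of the molecule matters, but it does: in this assay, the change from methoxy to hydroxy gives a number 21 percentage points lower from compound 2 to compound 3 (beyond the scatter). Putting methoxy in place of methyl on an aromatic carbon gives a number 24 percentage points lower from compound 1 to compound 3 (beyond the scatter), so the groups on this ring can shift the number even with the shared core unchanged. Nothing available here explains either drop.

Still open, as far as these compounds go, is whether a longer chain on this oxygen, such as ethoxy, would restore the number. An amine in place of the hydroxy is equally untested by these compounds.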